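The compounds below may be only part of what the source reports. "The series", "measured", "known", "first", "only" and "open" are said of these compounds alone.

Compound 1, with the structure `CN(C)CCC(NC(=O)c1ccc(C(F)(F)F)cc1)c1ccc(Cl)cc1`, gives 115% in an assay on NIH3T3 cells with Urotensin-2 receptor (Homo sapiens) as the target; on this read-out higher numbers stand for larger maximal responses and lower numbers for smaller maximal responses. Of the two values known on this read-out, that is the lowest; the other compound, compound 2 with the structure `COc1cccc(C(=O)NC(CCN(C)C)c2ccc(Cl)cc2)c1C`, gives 179% in this assay, a number beyond the scatter above compound 1. Compound 3, with the structure `CN(C)CCC(NC(=O)c1ccc(N(C)C)cc1)c1ccc(Cl)cc1`, has not yet been measured. It differs from compound 1 in one place: dimethylamino in place of trifluoromethyl on an aromatic carbon. Among the measured compounds shown here, no measured pair shows this change, so the step is expected to be small, and it is estimated at a number 5 percentage points higher from compound 1 to compound 3 (within the scatter) in this assay. For compound 3 the estimated efficacy in this assay is 120%, between 70% and 180%.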

Compound 3, largest response reached (reported as efficacy), in percent of the reference or control that the assay uses: 150%
Compound 3: middle estimate off by 30 percentage points, on the low side; the range from low to high includes it.
By their numbers in this assay, from the lowest: compound 1; then compound 3; then compound 2.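

In this assay, the step from trifluoromethyl to dimethylamino on an aromatic carbon, para to a large group, is a number 35 percentage points higher from compound 1 to compound 3 (beyond the scatter). Among the compounds shown here, this is the first sign that the maximal response depends on the group at this position, which no earlier pair could show, as compound 1 and compound 2 differ in more than one place.

The compounds shown leave open how a methoxy group, a primary amine or a carboxylic acid would behave at this position, and whether the same change would give a similar step on another part of the core. Nothing measured here accounts for the size of this step.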